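The source may hold more compounds than are shown below. What is called first, only, known or untested is meant among the compounds shown, and "the series" means these compounds.

Measured compounds:
- compound 1, `O=C(/C=C/c1ccco1)c1ccccc1OCC1CO1` — 24.2%
- compound 2, `O=C(/C=C/c1ccco1)c1cccc(OCC2CO2)c1` — "not determined" (no result reported)
- compound 3, `O=C(/C=C/c1cccs1)c1ccc(OCC2CO2)cc1` — "not determined" (no result reported)

The measure here is an assay for inhibition of DNA topoisomerase 1 (Homo sapiens), with a stated time of 30 min, tested at 20 uM; a higher number here means a stronger effect of the compound at the concentration tested, a lower number a weaker effect. Only compound 1 gives a number in it, and that number is 24.2%. Compound 2 returns "not determined" (no result reported), and compound 3 likewise returns "not determined" (no result reported), so compound 3 stands nowhere on the numbers: it shares the single-concentration read-out with compound 1 in name only, and no number of its own anchors it. Compound 3 and compound 2 together make two entries without a single result, against one entry with a result.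

The step under consideration leads from compound 3 to compound 4, `O=C(/C=C/c1ccsc1)c1ccc(OCC2CO2)cc1`. The two are built of the same atoms joined differently: thiophen-3-yl in place of thiophen-2-yl on a double-bonded chain carbon bound to a double-bonded chain carbon. Going by the values given here, no measured pair shows what such a change does in this assay, and no step between measured compounds exists at all, so the size of the step can only be guessed. The author expects a step of no more than the usual scatter in this assay, with no direction favoured, since nothing measured argues one way or the other.

Among the compounds with values here, for compound 4 the inhibition in this assay is expected to come out near 22%, with a likely range from 3% to 45%, an estimate resting on the single number from compound 1.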

Compound 4, a percentage reported as inhibition, at one concentration (the size of the read-out at that concentration, not a potency): 0%
Compound 4: middle estimate off by 22 percentage points, on the high side; the whole stated range lies above it.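

Going by these compounds alone, compound 3 stands at "not determined" (no result reported) and so no step can be read from it to compound 4, despite the single exchange of thiophen-2-yl for thiophen-3-yl. From the compounds shown here alone, what that exchange does in this assay remains open, as does how compound 4 compares with a close partner. No supporting evidence bears on the result for compound 4.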